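This account rests on a few compounds, and the source may have more. Where it says the series, first, only, none or still open, it means among the compounds named here.

Of the compounds shown here, two of the shared core have been measured. In an assay on cell membranes for displacement of a labelled ligand from Neuronal acetylcholine receptor; alpha4/beta2 (Rattus norvegicus) (on this read-out lower numbers stand for stronger inhibition and higher numbers for weaker inhibition), compound 2 `COc1ccc(Nc2ccc(N3CC4CC(C3)N4)nn2)cc1` gives 578 nM, the lowest of the two numbers. Compound 1 `Clc1cccc(Nc2ccc(N3CC4CC(C3)N4)nn2)c1` gives 1540 nM, a gap beyond the usual scatter, so compound 2 stands as the stronger binder of the pair. Compound 3 `Cc1ccc(Nc2ccc(N3CC4CC(C3)N4)nn2)cc1` is not yet measured; it differs from compound 2 by methyl in place of methoxy on an aromatic carbon. Going by the values given here, no measured pair shows what this exchange does, so the direction is open; the expected change, a 1.1-fold higher number from compound 2 to compound 3 (0.05 log units; within the scatter), is small and not beyond the scatter. For compound 3 the value in this assay is estimated at 650 nM, with a range from 220 nM to 1900 nM.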

Compound 3, inhibition constant: 44.3 nM
Estimate against measurement, compound 3: 15-fold (1.17 log units) above; the measured number lies below the stated range.
By their numbers in this assay, from the lowest: compound 3; then compound 2; then compound 1.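

In this assay, going by these compounds alone, the place para to a large group on the aromatic ring proves sensitive to a small exchange: methyl in place of methoxy gives a 13-fold lower number from compound 2 to compound 3 (1.12 log units; beyond the scatter) and loses a single heavy atom. 4-Methylphenyl in place of 3-chlorophenyl gives a 35-fold lower number from compound 1 to compound 3 (1.54 log units; beyond the scatter) and is the widest step so far. Nothing at hand explains either step.

Open, as far as these compounds go, is how ethyl or an amine at the same place would read. Also open, from the compounds shown here alone, is whether 4-chlorophenyl would follow compound 1 or compound 3.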